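Working notes: from compound 1 to compound 4

The source may report more compounds than this note shows. Statements on the series, on what has been measured and on what is new or still open speak of the compounds shown alone.

Measured in a functional assay on K562 cells (Homo sapiens) for inhibition, read by MTT assay, with a stated time of 48 h; a lower number here means a stronger inhibitor, a higher number a weaker inhibitor:
- compound 1 `Nc1ccc(-c2cn([C@@H]3CN[C@H](C(=O)Nc4ccc(Cl)c(C(F)(F)F)c4)C3)nn2)cn1` gives 10400 nM
- compound 2 `CC(=O)Nc1ccc(-c2cn([C@@H]3CN[C@H](C(=O)Nc4ccc(Cl)c(C(F)(F)F)c4)C3)nn2)cn1` gives 8980 nM
- compound 3 `CC(C)(C)OC(=O)N1C[C@@H](n2cc(-c3ccc4c(N)n[nH]c4c3)nn2)C[C@H]1C(=O)Nc1ccc(Cl)c(C(F)(F)F)c1` gives 10500 nM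

The three values lie within the scatter of one another, so compound 1 stands in a single cluster with compound 2 and compound 3, without a meaningful order. The step under review leads to compound 4 `Nc1n[nH]c2cc(-c3cn([C@@H]4CN[C@H](C(=O)Nc5ccc(Cl)c(C(F)(F)F)c5)C4)nn3)ccc12` and puts 3-amino-1H-indazol-6-yl in place of 6-aminopyridin-3-yl on an aromatic carbon. Going by the values given here, the only measured step (a 1.2-fold lower number from compound 1 to compound 2 (0.06 log units; within the scatter)) changes the amino nitrogen of the same 6-aminopyridin-3-yl group and stays within the scatter. Among the compounds with values here, compound 3 also bears 3-amino-1H-indazol-6-yl and gives 10500 nM in this assay but no measured step links it to compound 4, so it is only a loose guide. Within the data shown here, no measured step covers this exchange, so the range stays wide. No change beyond the scatter is expected in this assay and the estimated step is small (a 1.3-fold lower number from compound 1 to compound 4 (0.11 log units; within the scatter)). Compound 4 is estimated at 8000 nM with 3000 nM to 16000 nM as the expected range.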

Compound 4, half-maximal inhibitory concentration: 8320 nM
Estimate against measurement, compound 4: 1.0-fold (0.02 log units) below; the range from low to high includes it.
By their numbers in this assay, from the lowest: compounds 4, 2, 1 and 3 (each within the scatter of the next).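

Placing 3-amino-1H-indazol-6-yl on this aromatic carbon of the five-membered aromatic ring with 3 nitrogen gives a 1.3-fold lower number from compound 1 to compound 4 (0.10 log units; within the scatter) in this assay, so this position accepts 10 heavy atoms in place of 7 with no change beyond the scatter. The exchange against the acetylated group gives a 1.1-fold lower number from compound 2 to compound 4 (0.03 log units; within the scatter) and, with 3-amino-1H-indazol-6-yl held constant, hydrogen in place of tert-butoxycarbonyl on the ring amine nitrogen gives a 1.3-fold lower number from compound 3 to compound 4 (0.10 log units; within the scatter), so neither step separates these compounds. No measured evidence accounts for this flat response.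

Going by these compounds, whether any group on this carbon can move the number beyond the scatter remains open, for example a carboxylic acid or a morpholine. On these data alone, all four compounds also keep the chloro and trifluoromethyl groups on the amide side, so the effect of a nitrile there is unknown.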